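A few compounds are considered here, and "the series" means these few. Any claim that something is new, unique, unknown or untested is made for them only; others in the source may bear on it.

Working notes on the cyanoguanidine series.

Among the compounds with values here, compound 1 `CC/N=C(/NC#N)NCCCn1nc(-c2ccccc2)cc(C)c1=O` stands lowest of the two compounds measured so far in a functional assay on the whole organism with Rattus norvegicus as the target, at a dose of 100 mg/kg (on this read-out lower numbers stand for less inhibition and higher numbers for more inhibition at the one dose given (going by the name of the read-out)), where compound 1 gives 23.5%. Within the data shown here, its nearest neighbour is compound 2 `CC/N=C(/NC#N)NCCCn1nc(-c2ccccc2)ccc1=O`, which in this assay gives 62.9%; the one measured step, a number 39.4 percentage points higher from compound 1 to compound 2 (beyond the scatter), concerns a hydrogen in place of methyl on an aromatic carbon.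

Compound 3 `C/N=C(/NC#N)NCCCn1nc(-c2ccccc2)cc(C)c1=O` is not yet measured. It differs from compound 1 as follows: hydrogen in place of methyl on a saturated chain carbon bound to a double-bonded nitrogen. Among the measured compounds shown here, no measured step touches this part of the molecule; the step from compound 1 to compound 2 sits on the ring and does not bear on a change at the chain carbon bound to a double-bonded nitrogen. With nothing to lean on, the expectation for this assay is no step beyond the scatter, with wide uncertainty in either direction.

Compound 3 is therefore estimated at 25% in this assay, within 6% to 50%, an expected step of a number 1.5 percentage points higher from compound 1 to compound 3 (within the scatter).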

Compound 3, a percentage reported as inhibition, in the whole organism at one dose (the size of the read-out at that dose, not a potency): 42.8%
Beside the measured number, compound 3's estimate is 17.8 percentage points below it; the measured number falls inside the stated range.
By their numbers in this assay, from the lowest: compound 1; then compound 3; then compound 2.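

The end of the chain is a responsive position: ethyl to methyl, a hydrogen in place of methyl on a saturated chain carbon bound to a double-bonded nitrogen, gives in this assay a clear change (a number 19.3 percentage points higher from compound 1 to compound 3 (beyond the scatter)). Compound 1 now has two measured one-place neighbours, and losing a methyl raises the number at both places, the ring step being (a number 39.4 percentage points higher from compound 1 to compound 2 (beyond the scatter)). Nothing on hand accounts for the change at the chain position.

Whether the two changes add up when made on one molecule stays open, since no compound shown carries both. Also open, on these data alone, is how the read-out responds at the chain end to a propyl group, a longer chain, or a chain ending in a hydroxyl group or an amine.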